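Cytotoxicity outlook for compound 4 in the series

The source may hold more compounds than are shown below. What is called first, only, known or untested is meant among the compounds shown, and "the series" means these compounds.

Going by the values given here, the three measured members share one core and differ only in the aryl group at one end. In an ADME assay on THP-1 cells (Homo sapiens) for cytotoxicity, read by MTT assay (a lower number here means that less compound is tolerated, a higher number that more compound is tolerated), compound 1 `Cc1nc(-c2cccnc2)sc1-c1nnc(-c2ccc(Br)cc2)o1` gives > 100 ug/mL, which is a limit of the assay. In this assay compound 2 `Cc1nc(-c2cccnc2)sc1-c1nnc(-c2ccccc2)o1` gives > 100 ug/mL, again a limit. Compound 3 `Cc1nc(-c2cccnc2)sc1-c1nnc(-c2cccc(Cl)c2Cl)o1` gives > 100 ug/mL in this assay, also a limit and not a number. All three values thus sit together, as recorded in the limit of > 100 ug/mL in this assay, at which 3 of the 3 values shown sit, and compound 3 stands at the same limit as the other two rather than at a readable number.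

Of the measured steps, a step that the two limits leave unreadable from compound 1 to compound 2, a step that the two limits leave unreadable from compound 1 to compound 3 and a step that the two limits leave unreadable from compound 2 to compound 3 are all exchanges of the same aryl group, and none of them can be sized because both ends are limits.

Compound 4 `Cc1cccc(-c2nnc(-c3sc(-c4cccnc4)nc3C)o2)c1` arises from compound 3 by 3-methylphenyl in place of 2,3-dichlorophenyl on an aromatic carbon. This is a further aryl exchange of the kind covered by the three unreadable steps, so no readable step beyond the scatter is expected here; compound 4 is expected to sit at the same limit. The step from compound 3 to compound 4 is therefore estimated as a step that the limit leaves unreadable from compound 3 to compound 4. For compound 4 the estimate in this assay is 150 ug/mL, with a range of 80 ug/mL to 300 ug/mL.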

Compound 4, half-maximal cytotoxic concentration: > 100 ug/mL
Compound 4 ended at the assay's limit; the forecaster's own chance of this, stated with the estimate: 85%; the middle value does not contradict the limit.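

Compound 4 gives > 100 ug/mL in this assay, which is a limit and not a number. No new step can be read between compound 4 and compound 1, compound 2 or compound 3, as all four stand at one limit: the limit of > 100 ug/mL in this assay, at which 4 of the 4 values shown sit. The compounds shown leave open what concentration of any of them would be half-maximally cytotoxic, and whether the aryl exchanges differ at all.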